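Thiazole for pyrazole on the fused core

This account rests on a few compounds, and the source may have more. Where it says the series, first, only, none or still open, it means among the compounds named here.

Measured so far:
compound 1 `c1cc(-c2ccn[nH]2)c2c(c1)C(c1ncc[nH]1)CC2` — 52 nM
compound 2 `Cc1ccc2c(c1NS(C)(=O)=O)CCC2c1ncc[nH]1` — 33 nM

In a functional assay on CHO cells for agonist activity at Alpha-1A adrenergic receptor (Homo sapiens), read by FLIPR and calcium flux (a higher number here means that more compound is needed for the effect, a lower number that less compound is needed), compound 1 gives 52 nM, the higher of the two numbers, while compound 2 gives 33 nM; the gap between them is within the scatter, so neither is set apart. Compound 3 `c1cc(-c2nccs2)c2c(c1)C(c1ncc[nH]1)CC2` is the next entry and differs from compound 1 by 1,3-thiazol-2-yl in place of 1H-pyrazol-5-yl on an aromatic carbon. Within the data shown here, no measured pair isolates this change, so the expectation is an even one. Compound 3 is estimated at 80 nM, with a range from 25 nM to 250 nM. The step of a 1.5-fold higher number from compound 1 to compound 3 (0.19 log units; within the scatter) is expected to be small, toward a somewhat higher number, and may not exceed the scatter.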

Compound 3, half-maximal effective concentration: 426 nM
Beside the measured number, compound 3's estimate is 5.3-fold (0.73 log units) below it; the whole stated range lies below it.
By their numbers in this assay, from the lowest: compounds 2 and 1 (each within the scatter of the next); then compound 3.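

In this assay this aromatic carbon proves sensitive to which five-membered aromatic ring it carries: 1,3-thiazol-2-yl in place of 1H-pyrazol-5-yl gives an 8.2-fold higher number from compound 1 to compound 3 (0.91 log units; beyond the scatter) even though the heavy-atom count stays the same. The change also loses the hydrogen-bond donor and gains a hydrogen-bond acceptor, but this single pair cannot separate those counts from the sulfur atom. No measurement at hand accounts for the step.

Still open, on these data alone, is whether a methyl group on the pyrazole nitrogen, or an amine on the same aromatic carbon, would keep the number close to that of compound 1.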